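Swapping Bromine for Fluorine on a Carbamate Inhibitor

A few compounds are considered here, and "the series" means these few. Any claim that something is new, unique, unknown or untested is made for them only; others in the source may bear on it.

Three measured compounds share one core and differ only in a single group. In an assay on HEK293 cells for inhibition of acid ceramidase (Homo sapiens), with a stated time of 10 min (a lower number here means a stronger inhibitor, a higher number a weaker inhibitor), compound 1 `O=C(NCCCCc1ccccc1)n1c(=O)oc2ccc(-c3ccccc3)cc21` gives 42 nM, compound 2 `O=C(NCCCCc1ccccc1)n1c(=O)oc2ccc([N+](=O)[O-])cc21` gives 3 nM, and compound 3 `O=C(NCCCCc1ccccc1)n1c(=O)oc2ccc(Br)cc21` gives 22 nM. On these numbers compound 3 lies close to compound 1 but far from compound 2: a 1.9-fold lower number from compound 1 to compound 3 (0.28 log units; within the scatter), whereas a 7.3-fold higher number from compound 2 to compound 3 (0.87 log units; beyond the scatter). Compound 4 `O=C(NCCCCc1ccccc1)n1c(=O)oc2ccc(F)cc21` carries fluoro in place of bromo on an aromatic carbon. Among the compounds with values here, no measured step exchanges one halogen for another, so the two steps at this position are only indirect guides: a modest gain for nitro, and little difference between phenyl and bromo. Within the data shown here, with no closer precedent, only a small shift is expected: a 1.8-fold higher number from compound 3 to compound 4 (0.26 log units; within the scatter). Compound 4 is estimated at 40 nM, with a likely range from 10 nM to 150 nM.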

Compound 4, half-maximal inhibitory concentration: 12 nM
The estimate for compound 4 lay 3.3-fold (0.52 log units) above the measured number, within the range that was stated.
By their numbers in this assay, from the lowest: compound 2; then compounds 4, 3 and 1 (each within the scatter of the next, the first and the last beyond it).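

Exchanging one halogen for the other at this position stays within the usual scatter, with a 1.8-fold lower number from compound 3 to compound 4 (0.26 log units; within the scatter) as the step. Fluoro, unlike bromo, does separate from phenyl, with a 3.5-fold lower number from compound 1 to compound 4 (0.54 log units; beyond the scatter) as the gain, while nitro keeps a clear lead, with a 4.0-fold higher number from compound 2 to compound 4 (0.60 log units; beyond the scatter) as the loss on leaving it. Nothing measured here accounts for these differences. The compounds shown leave open whether chloro would fall with bromo and fluoro, and whether a nitrile or an amine on this aromatic carbon would come closer to nitro.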